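Piperazine Nitrogen Substituents and an Assay Limit

A few compounds are considered here, and "the series" means these few. Any claim that something is new, unique, unknown or untested is made for them only; others in the source may bear on it.

Compound 3 `Nc1nc(N2CCN(S(=O)(=O)c3ccccc3)CC2)c2nc(-c3ccc(F)cc3)sc2n1` belongs to a set of three analogues on a shared core. In a functional assay on cells (Lymphocyte, Homo sapiens) (a lower number here means a stronger inhibitor, a higher number a weaker inhibitor), compound 1 `Nc1nc(N2CCN(C(=O)COc3ccc(Cl)cc3)CC2)c2nc(-c3ccc(F)cc3)sc2n1` gives 490 nM. Compound 2 `CC(C)(Oc1ccc(Cl)cc1)C(=O)N1CCN(c2nc(N)nc3sc(-c4ccc(F)cc4)nc23)CC1` reaches only the limit of > 10000 nM in this assay. Compound 3 likewise sits at the limit of > 10000 nM in this assay. Two large steps are known, an at least 20-fold higher number from compound 1 to compound 2 (1.30 log units; beyond the scatter) and an at least 20-fold higher number from compound 1 to compound 3 (1.30 log units; beyond the scatter), both ending at the limit of > 10000 nM in this assay, at which 2 of the 3 values shown sit. Compound 4 `Cc1cccc(N2CCN(c3nc(N)nc4sc(-c5ccc(F)cc5)nc34)CC2)c1` differs from compound 3 by 3-methylphenyl in place of phenylsulfonyl on an amine nitrogen in a ring. As far as these compounds go, neither measured step starts from compound 3, so the size of this change is untested, and the limit for compound 3 gives no starting number. Compound 4 is expected to show an at least 2.5-fold lower number from compound 3 to compound 4 (0.39 log units; beyond the scatter). Compound 4 is estimated at 4000 nM, within 600 nM to 20000 nM.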

Compound 4, half-maximal inhibitory concentration: > 10000 nM
Compound 4 was reported as a limit; the forecaster's own chance of this, stated with the estimate: 35%; middle value at least 2.5-fold (0.39 log units) from the limit.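

Compound 4 gives > 10000 nM in this assay, which is a limit and not a number. The step from compound 3 cannot be read, since both ends are limits, but 3-methylphenyl on the ring nitrogen gives an at least 20-fold higher number from compound 1 to compound 4 (1.30 log units; beyond the scatter). A third substituent, this one carrying no hydrogen-bond acceptors, thus also fails to read below the limit, leaving compound 1 alone with a number: the limit of > 10000 nM in this assay, at which 3 of the 4 values shown sit.

As far as these compounds go, how far compound 2, compound 3 and compound 4 differ from one another stays open. So does whether a benzyl group or an acetyl group on that nitrogen would give a number.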